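Thiadiazole substituent swap on the unsubstituted benzofuran core

This account rests on a few compounds, and the source may have more. Where it says the series, first, only, none or still open, it means among the compounds named here.

Measured so far in a functional assay on HEK293 cells for antagonist activity at proteinase-activated receptor 4 (Homo sapiens), read by FLIPR and calcium flux, with a stated time of 30 min; a higher number here means a weaker inhibitor, a lower number a stronger inhibitor:
- compound 1 `COc1cc(OCc2cccc(COc3ccccc3)c2)c2cc(-c3cn4nc(OC)sc4n3)oc2c1` gives 3.2 nM
- compound 2 `CS(=O)(=O)c1nn2cc(-c3cc4ccccc4o3)nc2s1` gives 820 nM
- compound 3 `COc1cc(OCc2cccc(Oc3ccccc3)c2)c2cc(-c3cn4nc(OC)sc4n3)oc2c1` gives 1.2 nM

Compound 2 stands at the highest number of the three by a wide margin; compound 1 and compound 3 both sit far lower, and both also carry a methoxy at the position where compound 2 holds a methylsulfonyl, together with a substituted benzofuran that compound 2 lacks. For the measured compounds named here, the only step measured within one change of structure is a 2.7-fold lower number from compound 1 to compound 3 (0.43 log units; beyond the scatter), a modest one at a different place, so it says nothing about the thiadiazole substituent.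

Compound 4 `CC(C)Oc1nn2cc(-c3cc4ccccc4o3)nc2s1` differs from compound 2 in one place: isopropoxy in place of methylsulfonyl on an aromatic carbon. Going by the values given here, no measured pair isolates this change. The values of compound 1 and compound 3 show that an alkoxy group at this position is compatible with low numbers, but their other differences from compound 2 prevent any clean reading of the size. A move to a lower number in this assay is expected, of uncertain size, a 5.5-fold lower number from compound 2 to compound 4 (0.74 log units; beyond the scatter). For compound 4 the estimate is 150 nM, within 40 nM to 600 nM.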

Compound 4, half-maximal inhibitory concentration: 760 nM
Beside the measured number, compound 4's estimate is 5.1-fold (0.70 log units) below it, outside the stated range (above it).
By their numbers in this assay, from the lowest: compound 3; then compound 1; then compounds 4 and 2 (each within the scatter of the next).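

In this assay, for the compounds shown here, this is the first pair that isolates the substituent on the aromatic carbon of the five-membered ring with 2 nitrogen and 1 sulfur, and isopropoxy in place of methylsulfonyl gives a 1.1-fold lower number from compound 2 to compound 4 (0.03 log units; within the scatter) with the rest of the structure held constant. The two groups match in heavy-atom count but differ in their hydrogen-bond acceptor count and in double bonds outside aromatic rings, and on this core that exchange does not separate compound 2 from compound 4 in the read-out. No measurement at hand explains this result.

Still open, from the compounds shown here alone, is whether the exchange would read the same on the substituted benzofuran core of compound 1 and compound 3, since those two compounds differ from compound 4 in more than one place and so cannot assign their low numbers to any single group. Also open, going by these compounds, is how this carbon responds to groups of another kind, such as an amine, a carboxylic acid or a longer alkoxy chain, any of which would test whether the position is as indifferent as this one pair suggests.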